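This account rests on a few compounds, and the source may have more. Where it says the series, first, only, none or still open, it means among the compounds named here.

In a functional assay on HL-60 cells (Homo sapiens) for cytotoxicity, read by luminescence and CellTiter-Glo, with a stated time of 3 days (on this read-out higher numbers stand for weaker inhibition and lower numbers for stronger inhibition), compound 1 (`O=C(Nc1cc(F)cc(F)c1)c1ccc2cccnc2c1O`) gives 510 nM and compound 2 (`N#Cc1ccc(NC(=O)c2ccc(C(F)(F)F)cc2O)cc1`) gives 1030 nM, the higher of the two numbers, with the gap beyond the scatter. Compound 3 (`N#Cc1ccc(NC(=O)c2ccc(F)cc2O)cc1`) differs from compound 2 in one place: fluoro in place of trifluoromethyl on an aromatic carbon, meta to a hydroxy group and para to a large group (fluoro in place of trifluoromethyl on an aromatic carbon). Among the compounds with values here, no measured pair shows this change, so the expectation is loose. A modest move towards weaker inhibition in this assay is expected, estimated as a 1.7-fold higher number from compound 2 to compound 3 (0.24 log units; within the scatter). For compound 3 the estimated value is 1800 nM, with an expected range of 600 nM to 5500 nM.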

Compound 3, half-maximal inhibitory concentration: 1380 nM
Compound 3: the middle estimate sits 1.3-fold (0.12 log units) above what was measured; the measured number falls inside the stated range.
By their numbers in this assay, from the lowest: compound 1; then compounds 2 and 3 (each within the scatter of the next).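

In this assay, fluoro in place of trifluoromethyl on this aromatic carbon, para to a large group and meta to a hydroxy group, gives a 1.3-fold higher number from compound 2 to compound 3 (0.13 log units; within the scatter). At this position in this pair, the number therefore stays within the scatter when the group shrinks from trifluoromethyl to a single fluorine. No available data explain this outcome.

On these data alone, whether an amine, a methoxy group or a carboxylic acid at this carbon would also keep the number within the scatter remains open. This single pair also leaves open whether the same replacement would behave alike on another core.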